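One Aryl Ring for Another on a Sulfone Amide

This account rests on a few compounds, and the source may have more. Where it says the series, first, only, none or still open, it means among the compounds named here.

compound 1 `O=C(Nc1ccc(S(=O)(=O)N2CCCCC2)cc1)c1cc2cnccc2[nH]1`: > 10000 nM
compound 2 `O=C(NCc1ccc(S(=O)(=O)c2ccccc2C(F)(F)F)cc1)c1cc2cnccc2[nH]1`: 24 nM

For the measured compounds named here, in an assay for inhibition of Nicotinamide phosphoribosyltransferase (Homo sapiens), read by mass spectrometry, with stated times of 15 min and 30 min (on this read-out lower numbers stand for stronger inhibition and higher numbers for weaker inhibition), compound 2 gives the only number measured so far. Compound 1 gives no number, only a limit, (the limit of > 10000 nM in this assay, at which 1 of the 2 values shown sits). Compound 3 `Cc1cccc(S(=O)(=O)c2ccc(CNC(=O)c3cc4cnccc4[nH]3)cc2)c1` differs from compound 2 in one place: 3-methylphenyl in place of 2-(trifluoromethyl)phenyl on a sulfonyl sulfur. Going by the values given here, no measured pair shows a step of this kind, so the expectation rests on compound 2 alone; a step no larger than the scatter is expected, with no clear direction. Compound 3 is therefore estimated at 40 nM (from 10 nM to 160 nM), which means an expected step of a 1.7-fold higher number from compound 2 to compound 3 (0.22 log units; within the scatter).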

Compound 3, half-maximal inhibitory concentration: 8 nM
Compound 3: middle estimate off by 5.0-fold (0.70 log units), on the high side; measured number below the stated range.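

In this assay, the aryl group on the sulfonyl sulfur proves open to change: 3-methylphenyl in place of 2-(trifluoromethyl)phenyl gives a 3.0-fold lower number from compound 2 to compound 3 (0.48 log units; beyond the scatter) and shows that this position accepts one carbon-only aromatic ring for another, even with fewer heavy atoms and no fluorine. Nothing among the data shown accounts for this step. Still open, going by these compounds, is whether the step comes from the entering methyl, the departing trifluoromethyl or where each sits, and how a methoxy group, an amine or a pyridine ring would fare here.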